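Compound 1 and Its Trifluoromethyl Variant

The source may hold more compounds than are shown below. What is called first, only, known or untested is meant among the compounds shown, and "the series" means these compounds.

compound 1, `CCOC(=O)C1=C(Nc2ccccc2)S/C(=C\c2ccccc2)C1=O`: 23.6%
compound 2, `CCOC(=O)C1=C(Nc2ccccc2)S/C(=C\c2ccc(C(=O)O)cc2)C1=O`: < 10%

Among the measured compounds shown here, in a functional assay on MCF7 cells (Homo sapiens) for inhibition, read by MTT assay, with a stated time of 72 h, tested at 10 uM (on this read-out higher numbers stand for more inhibition at the one concentration tested (going by the name of the read-out) and lower numbers for less inhibition), compound 1 gives 23.6%, the only number reported. Compound 2, `CCOC(=O)C1=C(Nc2ccccc2)S/C(=C\c2ccc(C(=O)O)cc2)C1=O`, reaches only the limit < 10% in this assay. For the measured compounds named here, the one measured step is a number at least 13.6 percentage points lower from compound 1 to compound 2 (beyond the scatter), and the reading for compound 2 sits at the limit of < 10% in this assay, at which 1 of the 2 values shown sits.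

Compound 3, `CCOC(=O)C1=C(Nc2ccccc2)S/C(=C\c2ccccc2C(F)(F)F)C1=O`, differs from compound 1 by trifluoromethyl in place of hydrogen on an aromatic carbon. Going by the values given here, the only measured step concerns a carboxy group, so it bears on compound 3 only loosely and no step is expected beyond the scatter. Compound 3 is therefore estimated at 25%, with a range of 10% to 45%, a step of a number 1.4 percentage points higher from compound 1 to compound 3 (within the scatter) expected from compound 1.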

Compound 3, a percentage reported as inhibition, at one concentration (the size of the read-out at that concentration, not a potency): < 10%
Compound 3 ended at the assay's limit; the forecaster's own chance of this, stated with the estimate: 20%; at least 15 percentage points between middle value and limit.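

In this assay, trifluoromethyl in place of hydrogen on an aromatic carbon, ortho to a large group, gives a number at least 13.6 percentage points lower from compound 1 to compound 3 (beyond the scatter). Until now the only loss on this ring came with the carboxy group of compound 2, whereas this entering group has no hydrogen-bond donors, no hydrogen-bond acceptors and no net charge, so a loss here does not require a carboxy group. The reading for compound 3 is a limit of the assay and not a number, so the full size of the step stays unknown, and compound 3 now shares that limit with compound 2: the limit of < 10% in this assay, at which 2 of the 3 values shown sit.

The compounds shown leave open whether the loss follows the trifluoromethyl group itself or any replacement of hydrogen at this place, which a methyl group, a single fluorine or an amine there would help to separate. They also leave open whether trifluoromethyl on another carbon of the same ring would give the same result.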